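A few compounds are considered here, and "the series" means these few. Any claim that something is new, unique, unknown or untested is made for them only; others in the source may bear on it.

Measured so far:
- Compound 1, `C/C=C/C(=O)N(Cc1cc(OC)c(OC)c(OC)c1)c1ccc(OC)c(O)c1`, gives 6150 nM in a functional assay on MGC-803 cells (Homo sapiens) for inhibition, read by MTT assay, with a stated time of 48 h; a lower number here means a stronger inhibitor, a higher number a weaker inhibitor.
- Compound 2, `COc1ccc(CNc2cc(OC)c(OC)c(OC)c2)cc1C`, gives 56800 nM in this assay.
- Compound 3, `C/C=C/C(=O)N(Cc1ccc(OC)c(C)c1)c1cc(OC)c(OC)c(OC)c1`, gives 14500 nM in this assay.

Compound 2 has the highest number of the three, so it is the weakest inhibitor shown; the nearest is compound 3, and the step of a 3.9-fold lower number from compound 2 to compound 3 (0.59 log units; beyond the scatter) comes from placing a (prop-1-en-1-yl)carbonyl group on the nitrogen in place of hydrogen. Compound 1 lies furthest away, with a lower number still.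

Compound 4, `COc1ccc(CNc2cc(OC)c(OC)c(OC)c2)cc1`, has not yet been measured in this assay. Compared with compound 2 it differs in one place: hydrogen in place of methyl on an aromatic carbon. The methyl that leaves sits on an aromatic carbon of a six-membered aromatic ring of carbon only.

Among the measured compounds shown here, none of the measured steps touches that methyl. For the measured compounds named here, the only step recorded, from compound 2 to compound 3, alters the nitrogen, not the ring, so it says little about what removing one carbon from the ring will do. Going by the values given here, with no direct precedent, the expectation for compound 4 is a change that stays within the scatter, in no particular direction: the estimated step is a 1.1-fold higher number from compound 2 to compound 4 (0.02 log units; within the scatter).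

Compound 4 is therefore expected to give about 60000 nM in this assay, with a range from 25000 nM to 140000 nM.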

Compound 4, half-maximal inhibitory concentration: 11400 nM
Beside the measured number, compound 4's estimate is 5.3-fold (0.72 log units) above it; the whole stated range lies above it.
By their numbers in this assay, from the lowest: compounds 1, 4 and 3 (each within the scatter of the next, the first and the last beyond it); then compound 2.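

In this assay, the methyl on an aromatic carbon, ortho to a methoxy group, proves to matter: replacing it with hydrogen gives a 5.0-fold lower number from compound 2 to compound 4 (0.70 log units; beyond the scatter). Both steps measured from compound 2 are thus rated modest and lie beyond the scatter, since the other, at the nitrogen, is a 3.9-fold lower number from compound 2 to compound 3 (0.59 log units; beyond the scatter); a change of one carbon on the ring therefore registers in this assay just as adding the larger (prop-1-en-1-yl)carbonyl group to the nitrogen does. Nothing available explains why the compound with hydrogen at this carbon gives the lower number, so the result stands as an observation only.

The compounds shown have only methyl or hydrogen at this carbon, so they leave open how a fluorine atom or an ethyl group there would compare, and therefore whether the size of the group is what counts or something else about methyl. They also leave open whether removing the same methyl from compound 3, which carries the (prop-1-en-1-yl)carbonyl group on its nitrogen, would produce a similar step.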